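A few compounds are considered here, and "the series" means these few. Any claim that something is new, unique, unknown or untested is made for them only; others in the source may bear on it.

Of the compounds shown here, three with a shared core have been measured so far in a functional assay on HepG2 cells (Homo sapiens) for inhibition, read by MTT assay, with a stated time of 72 h (a higher number here means a weaker inhibitor, a lower number a stronger inhibitor), and their numbers span a modest range. Compound 1 `CCc1ccc(NC(=O)C2CCN(C/C=C/c3ccccc3)CC2)cc1` gives 23300 nM in this test, compound 2 `COc1cccc(NC(=O)C2CCN(C/C=C/c3ccccc3)CC2)c1` gives 78600 nM and compound 3 `COc1ccccc1NC(=O)C1CCN(C/C=C/c2ccccc2)CC1` gives 91200 nM there. Compound 3 therefore stands at the high end, level with compound 2 and clearly apart only from compound 1.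

Still unmeasured is compound 4 `O=C(Nc1cccc(Cl)c1)C1CCN(C/C=C/c2ccccc2)CC1` which has 3-chlorophenyl in place of 2-methoxyphenyl on an amide-type nitrogen. Going by the values given here, no measured step makes this exact exchange, so the evidence is indirect. Replacing 4-ethylphenyl with 3-methoxyphenyl gave a 3.4-fold higher number from compound 1 to compound 2 (0.53 log units; beyond the scatter) and replacing it with 2-methoxyphenyl gave a 3.9-fold higher number from compound 1 to compound 3 (0.59 log units; beyond the scatter) in the same test. Both steps are modest. Exchanging the two methoxyphenyl groups gave a 1.2-fold higher number from compound 2 to compound 3 (0.06 log units; within the scatter) and so made no difference that can be read. Among the compounds with values here, the only compound without a methoxy group thus has the lowest number, but this rests on compound 1 alone.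

In this assay a modest lowering of the number is therefore expected, estimated as a 1.9-fold lower number from compound 3 to compound 4 (0.28 log units; within the scatter) and uncertain in size. Compound 4 is estimated at 48000 nM with an expected range from 20000 nM to 105000 nM for now.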

Compound 4, half-maximal inhibitory concentration: 20000 nM
The estimate for compound 4 lay 2.4-fold (0.38 log units) above the measured number, and the stated range covers the measured number.
By their numbers in this assay, from the lowest: compounds 4 and 1 (each within the scatter of the next); then compounds 2 and 3 (each within the scatter of the next).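

In this assay, going by these compounds alone, the closest exchange, chloro in place of methoxy on an aromatic carbon, gave a 3.9-fold lower number from compound 2 to compound 4 (0.59 log units; beyond the scatter) and showed for the first time that a single substituent on this phenyl ring can shift the number beyond the scatter. The wider exchange of 3-chlorophenyl for 2-methoxyphenyl gave a 4.6-fold lower number from compound 3 to compound 4 (0.66 log units; beyond the scatter), while 3-chlorophenyl in place of 4-ethylphenyl gave a 1.2-fold lower number from compound 1 to compound 4 (0.07 log units; within the scatter), so compound 1 no longer stands alone and the split between the two compounds without a methoxy group and the two with one holds across all four, with none against it. Nothing available explains why these exchanges on the amide-type nitrogen behave in this way.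

Going by these compounds, it remains open whether the lower numbers depend on the chlorine itself or only on the absence of a methoxy group, and a plain phenyl, a 4-chlorophenyl or a 2-chlorophenyl would help to separate the two. On these data alone, how an amine or a carboxylic acid on this ring would fare is equally open, as is whether these differences would persist with any change to the rest of the shared core.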